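The source may report more compounds than this note shows. Statements on the series, on what has been measured and on what is new or still open speak of the compounds shown alone.

Measured so far:
- compound 1, `COCCOC(=O)c1cc(N)c(Nc2ccc(C#N)cc2)cc1Oc1c(C)cc(/C=C/C#N)cc1C`: 62 h
- compound 2, `COC(=O)c1cc(N)c(Nc2ccc(C#N)cc2)cc1Oc1c(C)cc(/C=C/C#N)cc1C`: 89 h

Compound 1 carries a methoxyethyl ester on the shared core, and compound 2 carries the plain methyl ester. Both were tested in an ADME assay on a cell-free system (plasma, Homo sapiens) for metabolic stability, read by LC-MS, tested at 10 ug/mL; on this read-out higher numbers stand for a longer-lived compound and lower numbers for a shorter-lived compound. On this read-out compound 2 gives the highest of the two numbers, and the step of a 1.4-fold higher number from compound 1 to compound 2 (0.16 log units; within the scatter) lies within the scatter, so the two compounds cannot be told apart on half-life.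

Compound 3, `Cc1cc(/C=C/C#N)cc(C)c1Oc1cc(Nc2ccc(C#N)cc2)c(N)cc1C(=O)OCCC#N`, has not been measured yet. It differs from compound 2 in one place: cyanomethyl in place of hydrogen on a saturated chain carbon bound to an oxygen next to a carbonyl group. Read one bond further out, the methyl ester becomes a 2-cyanoethyl ester, with a nitrile at the end of the chain.

Going by the values given here, the only measured step that bears on this change is a 1.4-fold higher number from compound 1 to compound 2 (0.16 log units; within the scatter), which also alters the chain on the ester oxygen and stayed within the scatter. On that evidence no step beyond the scatter is expected in this assay, so the change from compound 2 to compound 3 is estimated as a 1.2-fold lower number from compound 2 to compound 3 (0.07 log units; within the scatter). Compound 3 is therefore expected to give a half-life of about 75 h, within a range of 35 h to 160 h.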

Compound 3, half-life in the plasma assay: 32 h
The estimate for compound 3 lay 2.3-fold (0.37 log units) above the measured number; the whole stated range lies above it.
By their numbers in the plasma assay, from the lowest: compounds 3, 1 and 2 (each within the scatter of the next, the first and the last beyond it).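

Going by these compounds alone, in the plasma assay, a change in the chain on the ester oxygen moves the half-life beyond the scatter for the first time, with methyl giving way to 2-cyanoethyl: a 2.8-fold lower number from compound 2 to compound 3 (0.44 log units; beyond the scatter), so this position does respond to what is attached there. The two longer chains still cannot be told apart, since exchanging the end methoxy for cyano gives a 1.9-fold lower number from compound 1 to compound 3 (0.29 log units; within the scatter), so only the contrast between the methyl ester and the 2-cyanoethyl ester is clear. The same change from methyl to 2-cyanoethyl also registers in a physicochemical assay for solubility, read by HPLC, with a stated time of 4 h, at pH 2 (on this read-out lower numbers stand for lower solubility and higher numbers for higher solubility), where compound 2 gives 21.8 ug/mL and compound 3 gives 0.94 ug/mL and there the step is large: the measured solubility of compound 2, 21.8 ug/mL, and of compound 3, 0.94 ug/mL, a 23-fold lower number (1.37 log units; beyond the scatter)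

The compounds shown cannot tell whether the shorter half-life comes from the nitrile or from the longer chain, and they give no link between the half-life and the solubility. A plain propyl ester, which has a chain of similar length without the nitrile, would help to separate these two possibilities.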